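The source may hold more compounds than are shown below. What is called first, only, known or untested is meant among the compounds shown, and "the series" means these compounds.

Compound 3 `Cc1ccc(C)c(/C=C(/SCc2ccc(Cl)cc2)C(=O)c2ccc(Cl)cc2)c1` is one of three compounds tested in a functional assay on DU-145 cells (Homo sapiens) for inhibition, read by trypan blue exclusion, with a stated time of 96 h; on this read-out lower numbers stand for stronger inhibition of growth and higher numbers for weaker inhibition of growth. In this assay compound 3 gives 10000 nM, level with compound 1 `COc1ccccc1/C=C(/SCc1ccc(C)cc1)C(=O)c1ccc(Cl)cc1`, which gives 10000 nM; together these two stand at the highest number of the set, while compound 2 `Cc1ccc(CS/C(=C/c2cc([N+](=O)[O-])ccc2F)C(=O)c2ccc(Cl)cc2)cc1` gives 1000 nM. Going by the values given here, the single step measured between two compounds differing in one place, a 10-fold lower number from compound 1 to compound 2 (1.00 log units; beyond the scatter), concerns another part of the shared core. Compound 4 `Cc1ccc(CS/C(=C/c2cc(C)ccc2C)C(=O)c2ccc(Cl)cc2)cc1` differs from compound 3 by methyl in place of chloro on an aromatic carbon. Among the compounds with values here, no measured step tests this particular change, so no shift beyond the scatter is expected, and the expected step is no change at the digits printed from compound 3 to compound 4 (within the scatter). Compound 4 is therefore estimated at 10000 nM, within a range from 4000 nM to 25000 nM.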

Compound 4, concentration for 50% growth inhibition: 10000 nM
The estimate for compound 4 equals the measured number at the digits printed; the measured number falls inside the stated range.
By their numbers in this assay, from the lowest: compound 2; then compounds 1, 3 and 4 (each within the scatter of the next).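

In this assay, 4-methylbenzyl in place of 4-chlorobenzyl on the sulfur gives no change at the digits printed from compound 3 to compound 4 (within the scatter), so at this position the two groups cannot be told apart. With 4-methylbenzyl held fixed, the other aryl group does matter: there is a 10-fold higher number from compound 2 to compound 4 (1.00 log units; beyond the scatter), but no change at the digits printed from compound 1 to compound 4 (within the scatter). No evidence is available to explain these results. On these data alone, whether methyl and chloro also match when 2-fluoro-5-nitrophenyl is present remains open. So does the effect of an amine or a carboxylic acid at the position para to the large group.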